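A few compounds are considered here, and "the series" means these few. Any claim that something is new, unique, unknown or untested is made for them only; others in the source may bear on it.

Measured so far:
compound 1, `c1ccc(Oc2ccc3c(NCCCNCc4ccco4)ccnc3c2)cc1`, 14500 nM;
compound 2, `COc1ccc(F)cc1CNCCCNc1ccnc2cc(Cc3ccccc3)ccc12`, 4200 nM;
compound 3, `c1coc(CNCCCNc2ccnc3cc(C4CCCCC4)ccc23)c1`, 4200 nM.

In a physicochemical assay for solubility, with a stated time of 18 h, at pH 7.4 (on this read-out lower numbers stand for lower solubility and higher numbers for higher solubility), compound 3 stands level with compound 2 at the digits shown, and the two are together the lowest of the three numbers; compound 1 lies highest, as the step of a 3.5-fold lower number from compound 1 to compound 3 (0.54 log units; beyond the scatter) shows, which is beyond the scatter.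

Compound 4, `c1ccc(Cc2ccc3c(NCCCNCc4ccco4)ccnc3c2)cc1`, has not yet been measured. It differs from compound 3 in one place: benzyl in place of cyclohexyl on an aromatic carbon. Among the compounds with values here, the one measured step that touches this position is a 3.5-fold lower number from compound 1 to compound 3 (0.54 log units; beyond the scatter), a modest change going from phenoxy to cyclohexyl. Within the data shown here, for benzyl at the same place there is no measured step; compound 2 carries benzyl there and in this assay compound 2 gives 4200 nM, the same figure as compound 3, though compound 2 differs from compound 4 elsewhere as well, so that pair gives only a hint. Compound 4 is therefore expected to sit close to compound 3, with a step of a 1.2-fold higher number from compound 3 to compound 4 (0.08 log units; within the scatter) that may well fall within the scatter. The estimate for compound 4 is 5000 nM, with a range from 2000 nM to 12000 nM.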

Compound 4, solubility: 4200 nM
For compound 4 the middle estimate is 1.2-fold (0.08 log units) above the measured one; the measured number falls inside the stated range.
By their numbers in this assay, from the lowest: compounds 2, 3 and 4 (each within the scatter of the next); then compound 1.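

Benzyl in place of cyclohexyl on this aromatic carbon gives no change at the digits printed from compound 3 to compound 4 (within the scatter) in this assay and so shows that a non-aromatic and an aromatic six-membered ring of carbon are not told apart here, even with benzyl's additional carbon. Benzyl in place of phenoxy gives a 3.5-fold lower number from compound 1 to compound 4 (0.54 log units; beyond the scatter) and matches a 3.5-fold lower number from compound 1 to compound 3 (0.54 log units; beyond the scatter) in size, so among these three groups compound 1 with phenoxy alone stands apart. With benzyl held in place, furan-2-yl in place of 5-fluoro-2-methoxyphenyl on the saturated chain carbon gives no change at the digits printed from compound 2 to compound 4 (within the scatter) and adds a second change that leaves the number where it was.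

Going by these compounds, how a morpholine or a carboxylic acid at this aromatic carbon would read remains open. No evidence is at hand on why phenoxy stands apart.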